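The compounds below may be only part of what the source reports. "The series", "measured", "known", "first", "only" and "open" are said of these compounds alone.

Compound 1 `CCSC(=S)SCC(=O)c1ccc(NC(=O)c2cnc3ccccc3c2)cc1` gives 50000 nM
Compound 2 `COCCSC(=S)SCC(=O)c1ccc(OC)cc1` gives 7880 nM

In a functional assay on HeLa cells (Homo sapiens) for cytotoxicity, read by resazurin assay, with a stated time of 72 h (on this read-out higher numbers stand for weaker inhibition and lower numbers for stronger inhibition), compound 2 holds the lower of the two numbers, and its gap to compound 1 lies beyond the scatter. Compound 3 `COc1ccc(C(=O)CSC(=S)SCCOc2ccccc2)cc1` is still unmeasured. Its difference from compound 2 is phenyl in place of methyl on an oxygen on a saturated carbon. Among the compounds with values here, no measured pair shows this change, so the expectation rests on compound 2 at 7880 nM alone. In this assay the expected step of a 1.6-fold lower number from compound 2 to compound 3 (0.20 log units; within the scatter) is small, toward stronger inhibition, and within the scatter. For compound 3 the estimate is 5000 nM with an expected range from 1800 nM to 15000 nM in this assay.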

Compound 3, half-maximal inhibitory concentration: 5460 nM
Beside the measured number, compound 3's estimate is 1.1-fold (0.04 log units) below it, within the range that was stated.
By their numbers in this assay, from the lowest: compounds 3 and 2 (each within the scatter of the next); then compound 1.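

In this assay, phenyl in place of methyl on an oxygen on a saturated carbon gives a 1.4-fold lower number from compound 2 to compound 3 (0.16 log units; within the scatter), so this position carries a six-membered aromatic ring with no step beyond the scatter. Compound 2 alone could not show that tolerance. Nothing available explains the result. Still open, on these data alone, is whether an amine or a carboxylic acid on the phenyl ring, or a longer chain between that oxygen and the sulfur, would shift the number beyond the scatter. As far as these compounds go, the same change on the core of compound 1 also remains open.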